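Swapping Chloro for Methyl in a Sigma-1 Ligand

A few compounds are considered here, and "the series" means these few. Any claim that something is new, unique, unknown or untested is made for them only; others in the source may bear on it.

Measured compounds:
compound 1, `CN(CCCCn1c(=O)oc2ccccc21)Cc1ccc(Cl)cc1`: 7.1 nM
compound 2, `Cc1ccc(CN(C)CCCn2c(=O)oc3ccccc32)cc1`: 871 nM

Of the compounds shown here, two have been measured in an assay on membranes from liver for displacement of a labelled ligand from Sigma non-opioid intracellular receptor 1 (Rattus norvegicus), read by scintillation counting; on this read-out higher numbers stand for weaker inhibition and lower numbers for stronger inhibition. Compound 1 gives 7.1 nM, the lower of the two numbers. Compound 2 gives 871 nM, and its gap to compound 1 lies well beyond the scatter; as these two structures differ in more than one place, the gap cannot be assigned to any single change. Compound 3, `Cc1ccc(CN(C)CCCCn2c(=O)oc3ccccc32)cc1`, remains to be measured. It differs from compound 1 by methyl in place of chloro on an aromatic carbon. No single-change comparison is available to anchor this exchange, so the expectation rests on compound 1 alone. A modest weakening is expected, with the step estimated at a 3.5-fold higher number from compound 1 to compound 3 (0.55 log units; beyond the scatter). Compound 3 is accordingly expected to give about 25 nM, in a range from 6 nM to 100 nM.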

Compound 3, inhibition constant: 97 nM
Estimate against measurement, compound 3: 3.9-fold (0.59 log units) below, and the stated range covers the measured number.
By their numbers in this assay, from the lowest: compound 1; then compound 3; then compound 2.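

In this assay, going by these compounds alone, methyl in place of chloro gives a 14-fold higher number from compound 1 to compound 3 (1.14 log units; beyond the scatter), the first reading of a single change at this position. The earlier pair could not show this, as compound 1 and compound 2 differ in more than one place. Here the change sits on an aromatic carbon, para to a large group, and the step is large although each group counts one heavy atom, no ring and no net charge, so these counts alone do not set the result; no measurement available here explains the size of the step. From the compounds shown here alone, whether fluoro, methoxy or trifluoromethyl at this place would give a number closer to that of compound 1 or that of compound 3 remains open. So does whether this exchange would give a step of similar size on a shorter or longer chain.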